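Extending the Benzyloxy Arm: From Bromo to Methoxyphenyl

The source may hold more compounds than are shown below. What is called first, only, known or untested is meant among the compounds shown, and "the series" means these compounds.

Compound 1, `O=C(O)CCc1ccc2oc(-c3ccccc3)cc2c1`: 92%
Compound 2, `O=C(O)CCc1ccc(OCc2cccc(Br)c2)cc1`: 99%
Compound 3, `O=C(O)CCc1ccc(OCc2ccc(Oc3ccccc3)cc2)cc1`: 98%

Three propanoic acids were examined in a functional assay on 1321-N1 cells for agonist activity at Free fatty acid receptor 1 (Homo sapiens), read by calcium flux; on this read-out higher numbers stand for larger maximal responses and lower numbers for smaller maximal responses. In this assay compound 1 gives 92%, compound 2 gives 99%, and compound 3 gives 98%. Compound 2 carries the top number of the three, yet its neighbours offer no real separation: compound 3 sits one point lower and compound 1 seven points lower, and both of those gaps lie within the usual scatter of repeated runs. All three compounds therefore behave as essentially full agonists on this read-out, and no structural trend can be read from the numbers.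

The next compound, compound 4, `COc1ccccc1-c1cccc(COc2ccc(CCC(=O)O)cc2)c1`, is derived from compound 2 by a single substitution: 2-methoxyphenyl in place of bromo on an aromatic carbon. Compound 3 already shows that a larger aromatic extension on the benzyl ether is tolerated with a maximal response near the ceiling, so a step from compound 2 to compound 4 of any size beyond the scatter is not expected in this assay, and the direction, if any, is expected to be flat. Compound 4 is accordingly estimated to give 96% in this assay, within a range of 82% to 108%, which corresponds to an expected change of a number 3 percentage points lower from compound 2 to compound 4 (within the scatter).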

Compound 4, largest response reached (reported as efficacy), in percent of the reference or control that the assay uses: 105%
Estimate against measurement, compound 4: 9 percentage points below; measured number inside the range.
By their numbers in this assay, from the lowest: compounds 1, 3, 2 and 4 (each within the scatter of the next, the first and the last beyond it).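

In this assay, within the data shown here, 2-methoxyphenyl in place of bromo on this aromatic carbon, meta to a large group, gives a number 6 percentage points higher from compound 2 to compound 4 (within the scatter) and this is the first step that can be read between two compounds differing in one place. It shows that this position takes an entering group of 8 heavy atoms, with one six-membered aromatic ring and one hydrogen-bond acceptor, in place of a single bromine, while the maximal response stays within the scatter of that of compound 2. Nothing available here bears on why the response holds across this change.

The compounds shown leave open whether the methoxy of the entering group contributes anything, which a plain phenyl at the same carbon would test, and whether the response would also hold with an amine or a carboxylic acid there. They also leave open how this change affects the concentration needed for a response, as this assay records only the largest response reached and cannot separate compounds that all sit this close together.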